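Removing the propyl group from a receptor modulator core

The compounds below may be only part of what the source reports. "The series", "measured", "known", "first", "only" and "open" are said of these compounds alone.

Measured so far, in a functional assay for binding affinity to metabotropic glutamate receptor 2 (Homo sapiens), read by GTPgammaS binding, with a stated time of 1 h, at 30 degrees C; on this read-out lower numbers stand for an effect already at smaller amounts and higher numbers for an effect only at larger amounts of compound:
Compound 1 `CCCc1c(OCCCCOc2ccc(-c3nn[nH]n3)cc2)ccc2c1ccn2CC(C)(C)C` gives 559 nM
Compound 2 `CCCc1c(OCCCCOc2ccc(-c3nn[nH]n3)cc2)ccc2c1ccn2C(C)C` gives 1130 nM

Compound 1 has the lower of the two numbers. Compound 2 differs from it only in the group on the aromatic nitrogen, isopropyl in place of neopentyl, and that step is a 2.0-fold higher number from compound 1 to compound 2 (0.31 log units; beyond the scatter), a modest shift but beyond the scatter.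

Compound 3 `CC(C)(C)Cn1ccc2cc(OCCCCOc3ccc(-c4nn[nH]n4)cc3)ccc21` keeps the neopentyl group and the whole chain to the tetrazole, and differs from compound 1 only by hydrogen in place of propyl on an aromatic carbon. Among the measured compounds shown here, no measured step touches this position: the single step known, a 2.0-fold higher number from compound 1 to compound 2 (0.31 log units; beyond the scatter), concerns the aromatic nitrogen, not the aromatic carbon that carries the propyl. The direction of the change is therefore open, and only a cautious expectation can be given, a step of a 2.0-fold higher number from compound 1 to compound 3 (0.29 log units; within the scatter). For compound 3 the expected value in this assay is 1100 nM, with a range from 350 nM to 3500 nM.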

Compound 3, half-maximal effective concentration: 3590 nM
Beside the measured number, compound 3's estimate is 3.3-fold (0.51 log units) below it; the measured number lies above the stated range.
By their numbers in this assay, from the lowest: compound 1; then compound 2; then compound 3.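

In this assay, the propyl group on the aromatic carbon clearly matters: replacing it with hydrogen gives a 6.4-fold higher number from compound 1 to compound 3 (0.81 log units; beyond the scatter) and so takes a larger amount of compound to reach the half-maximal effect. Among the compounds shown here, this is the first measured change at this position, and the step is larger than the one on the aromatic nitrogen, which is a 2.0-fold higher number from compound 1 to compound 2 (0.31 log units; beyond the scatter) in the same assay. Nothing measured here explains why removing propyl has this effect.

As far as these compounds go, it remains open whether a methyl, an ethyl or a longer chain such as butyl on this aromatic carbon would give a lower or higher number than propyl. From the compounds shown here alone, it is also open whether removing propyl would have a similar effect with isopropyl rather than neopentyl on the aromatic nitrogen.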